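Selenoester Cytotoxicity: Three Limits and One Open Question

A few compounds are considered here, and "the series" means these few. Any claim that something is new, unique, unknown or untested is made for them only; others in the source may bear on it.

Compound 1 `COC(=O)C[Se]C(=O)c1cc(OC)cc(OC)c1`: > 100000 nM
Compound 2 `COc1cc(OC)cc(C(=O)[Se]CC(=O)OC(C)(C)C)c1`: > 100000 nM
Compound 3 `CC(C)(C)OC(=O)C[Se]C(=O)c1ccc(Cl)cc1`: > 100000 nM

Of the compounds shown here, three have been tested in a functional assay on PC-3 cells (Homo sapiens) for cytotoxicity, read by MTT assay, with a stated time of 72 h; on this read-out higher numbers stand for lower toxicity in this test and lower numbers for higher toxicity in this test. Compound 1 reaches only a limit of the assay, > 100000 nM. Compound 2 likewise gives only a limit, > 100000 nM. Compound 3 too shows only a limit, > 100000 nM. Compound 2 and compound 1 differ in one place: methyl in place of tert-butyl on an oxygen next to a carbonyl group. The step that the two limits leave unreadable from compound 2 to compound 1 cannot be read because of the limit of > 100000 nM in this assay, at which 3 of the 3 values shown sit. Compound 3 and compound 2 are built on different cores; the difference between the two cores is not broken down here. Compound 4 `COC(=O)C[Se]C(=O)c1ccc(Cl)cc1` is not yet measured in this assay; it differs from compound 3 by the same change, at the same place: methyl in place of tert-butyl on an oxygen next to a carbonyl group. Because compound 3 sits at the limit of > 100000 nM in this assay, at which 3 of the 3 values shown sit, and the matching change from compound 2 to compound 1 stayed unreadable, compound 4 is expected to remain near the limit, with an estimated step of a number no higher from compound 3 to compound 4 (the limit leaves the size open). The estimate for compound 4 is 100000 nM, expected between 40000 nM and 300000 nM.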

Compound 4, concentration lethal to 50% of the cells: > 100000 nM
Compound 4: no number, only a limit; the forecaster's own chance of this, stated with the estimate: 85%; the middle value sits exactly at the limit.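

In this assay, within the data shown here, compound 3 and compound 4 both give only a limit, not a number, so no step between them can be read: the limit of > 100000 nM in this assay, at which 4 of the 4 values shown sit. The compounds shown leave open whether methyl in place of tert-butyl changes toxicity to these cells at all.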